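The source may report more compounds than this note shows. Statements on the series, on what has been measured and on what is new or still open speak of the compounds shown alone.

Measured in a functional assay on NCI-H460 cells (Homo sapiens) for inhibition, read by MTT assay, with a stated time of 72 h; a higher number here means a weaker inhibitor, a lower number a stronger inhibitor
- compound 1 (`COc1cc(NC(C)CCCNC(=O)Nc2ccc(Br)cc2)c2ncccc2c1`) gives 30000 nM
- compound 2 (`COc1cc(NC(C)CCCNC(=O)Nc2ccc(C(F)(F)F)cc2)c2ncccc2c1`) gives 24000 nM

For the measured compounds named here, compound 2 at 24000 nM cannot be separated from compound 1, the only other measured compound, since the two values lie within the scatter of each other. Compound 3 (`COc1cc(NC(C)CCCNC(=O)Nc2cccc(C(F)(F)F)c2)c2ncccc2c1`) has the same atoms as compound 2, joined differently. The change is 3-(trifluoromethyl)phenyl in place of 4-(trifluoromethyl)phenyl on an amide-type nitrogen, and the group stays on the amide-type nitrogen.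

Going by the values given here, the one measured step, a 1.3-fold lower number from compound 1 to compound 2 (0.10 log units; within the scatter), exchanges one group for another rather than rearranging a group, so it bears only loosely on this change. Among the compounds with values here, it stayed within the scatter, and no measured step covers a rearrangement of this kind. The expected step in this assay is therefore none beyond the scatter, with no firm direction, and the estimate is a 1.1-fold lower number from compound 2 to compound 3 (0.04 log units; within the scatter). The estimated value for compound 3 is 22000 nM, with an expected range from 10000 nM to 45000 nM.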

Compound 3, half-maximal inhibitory concentration: 21000 nM
Compound 3: the middle estimate sits 1.0-fold (0.02 log units) above what was measured, within the range that was stated.
By their numbers in this assay, from the lowest: compounds 3, 2 and 1 (each within the scatter of the next).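

In this assay, 3-(trifluoromethyl)phenyl in place of 4-(trifluoromethyl)phenyl on the amide-type nitrogen gives a 1.1-fold lower number from compound 2 to compound 3 (0.06 log units; within the scatter), so this first rearrangement of a group at this position does not separate the two compounds. Exchanging 4-bromophenyl for 3-(trifluoromethyl)phenyl at the same nitrogen gives a 1.4-fold lower number from compound 1 to compound 3 (0.15 log units; within the scatter), so a change of both the group and its placement also leaves the values unseparated. There is no evidence available that bears on these results.

The three compounds shown leave open whether any group on this amide-type nitrogen can move the number in this cell assay beyond the scatter. An amine or a carboxylic acid on the phenyl ring, or a longer chain joining the shared core to the carbonyl, would put that question to the test.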